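The source may hold more compounds than are shown below. What is called first, only, known or untested is meant among the compounds shown, and "the series" means these compounds.

Measured so far:
compound 1, `c1ccc(CNC2CCN(CCCc3c[nH]c4ccc(-n5cnnc5)cc34)CC2)cc1`, in an assay on CHO cells for agonist activity at 5-hydroxytryptamine receptor 1D (Homo sapiens), read by GTPgammaS binding (on this read-out lower numbers stand for an effect already at smaller amounts and higher numbers for an effect only at larger amounts of compound), gives 7.6 nM;
compound 2, `COC[C@H](NC1CCN(CCCc2c[nH]c3ccc(-n4cnnc4)cc23)CC1)c1ccccc1`, gives 0.9 nM;
compound 3, `CC(CO)(NC1CCN(CCCc2c[nH]c3ccc(-n4cnnc4)cc23)CC1)c1ccccc1`, gives 3.4 nM.

Among these three, compound 1 stands highest: compound 3 is nearest, with a 2.2-fold lower number from compound 1 to compound 3 (0.35 log units; beyond the scatter), and compound 2 furthest, with an 8.4-fold lower number from compound 1 to compound 2 (0.93 log units; beyond the scatter). The unmeasured compound 4, `C[C@H](NC1CCN(CCCc2c[nH]c3ccc(-n4cnnc4)cc23)CC1)c1ccccc1`, differs from compound 1 in one place: methyl in place of hydrogen on a saturated chain carbon bound to an amine nitrogen and an aromatic carbon.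

Within the data shown here, the step that bears most directly on this change is the one from compound 1 to compound 2, where a methoxymethyl group enters on the same saturated chain carbon bound to an amine nitrogen and an aromatic carbon, and the number fell by an 8.4-fold lower number from compound 1 to compound 2 (0.93 log units; beyond the scatter). The step from compound 1 to compound 3, which replaces benzyl with 1-(hydroxymethyl)-1-phenylethyl on the amine nitrogen, also brought a lower number, a 2.2-fold lower number from compound 1 to compound 3 (0.35 log units; beyond the scatter). Both substitutions at or near this carbon gave lower numbers, though the methyl entering in compound 4 carries no oxygen, so a smaller step than that to compound 2 seems likely.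

Compound 4 is therefore expected to give a lower number than compound 1, an estimated step of a 2.5-fold lower number from compound 1 to compound 4 (0.40 log units; beyond the scatter). The estimate for compound 4 in this assay is 3 nM, with a range from 1 nM to 9 nM.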

Compound 4, half-maximal effective concentration: 12 nM
Estimate against measurement, compound 4: 4.0-fold (0.60 log units) below, outside the stated range (above it).
By their numbers in this assay, from the lowest: compound 2; then compound 3; then compounds 1 and 4 (each within the scatter of the next).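

In this assay, methyl in place of hydrogen on a saturated chain carbon bound to an amine nitrogen and an aromatic carbon does not separate the two compounds (a 1.6-fold higher number from compound 1 to compound 4 (0.20 log units; within the scatter)), so filling this place with a carbon group does not in itself bring the lower number seen for compound 2. The steps from the oxygen-bearing compounds show where the difference lies: hydrogen in place of methoxy is a large step (a 13-fold higher number from compound 2 to compound 4 (1.12 log units; beyond the scatter)), and 1-phenylethyl in place of 1-(hydroxymethyl)-1-phenylethyl on the amine nitrogen is a modest one (a 3.5-fold higher number from compound 3 to compound 4 (0.55 log units; beyond the scatter)), so among these four compounds the lower numbers go only with the two substituents that carry oxygen. Nothing shown explains this difference.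

The compounds shown leave open whether oxygen is what matters or whether a longer chain would serve as well, as an ethyl or propyl group on this carbon would test against the methoxymethyl of compound 2. They also leave open how an amine or a carboxylic acid at the end of such a chain would read, and how the mirror-image form of compound 4 would compare.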